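The compounds below may be only part of what the source reports. "The series", "measured", "known", "first", "only" and "open" are said of these compounds alone.

In an ADME assay on microsomes from liver (Homo sapiens) for metabolic stability, with a stated time of 10 min (on this read-out higher numbers stand for a more stable compound and lower numbers for a less stable compound), compound 2 `CS(=O)(=O)NC(=O)c1ccc(Nc2nc(NC3(c4ccc(Cl)cc4)CC3)nc(OCC(F)(F)F)n2)cc1` gives 100% and stands level with compound 1 `CC(C)OC(=O)NCCS(=O)(=O)NC(=O)c1ccc(Nc2nc(NC3(c4ccc(Cl)cc4)CC3)nc(OCC(F)(F)F)n2)cc1`, which in this assay gives 100%. The step of no change at the digits printed from compound 1 to compound 2 (within the scatter) shows that the read-out did not move when the chain on the saturated chain carbon bound to a sulfonyl sulfur was removed. Compound 3 `CC(C)NC(=O)NCCS(=O)(=O)NC(=O)c1ccc(Nc2nc(NC3(c4ccc(Cl)cc4)CC3)nc(OCC(F)(F)F)n2)cc1` carries ((isopropylcarbamoyl)amino)methyl in place of hydrogen on a saturated chain carbon bound to a sulfonyl sulfur. Because no change at the digits printed from compound 1 to compound 2 (within the scatter) stayed within the scatter, the step of no change at the digits printed from compound 2 to compound 3 (within the scatter) is expected to be none beyond the scatter. Compound 3 is therefore estimated to give 100% in this assay, within a range from 90% to 100%.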

Compound 3, percent of the compound remaining: 100%
Estimate against measurement, compound 3: no gap at the digits printed, within the range that was stated.
By their numbers in this assay, from the lowest: compounds 1, 2 and 3 (each within the scatter of the next).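

In this assay the second chain-bearing compound gives no change at the digits printed from compound 2 to compound 3 (within the scatter) with ((isopropylcarbamoyl)amino)methyl in place of hydrogen on the saturated chain carbon bound to a sulfonyl sulfur, so a second such chain also leaves the read-out in place. Isopropylamino in place of isopropoxy on a carbonyl carbon, a change not shown before, gives no change at the digits printed from compound 1 to compound 3 (within the scatter) and separates the two chains no further. No evidence on hand bears on this result. From the compounds shown here alone, whether a chain ending in an amine or a carboxylic acid, or a longer chain, would hold the same level in this assay stays open.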